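Replacing 4-(dimethylamino)phenyl with ethoxy in compound 3

The compounds below may be only part of what the source reports. "The series", "measured", "known", "first", "only" and "open" are said of these compounds alone.

Values in a functional assay on Ehrlich cells (Mus musculus) for cytotoxicity, read by trypan blue exclusion, with a stated time of 2 h; on this read-out lower numbers stand for stronger inhibition and higher numbers for weaker inhibition:
Compound 1 `N#CC1=C(NC(=O)c2ccccc2)N(c2ccc(S(N)(=O)=O)cc2)C2=C(C(=O)CCC2)C1c1ccc(Cl)cc1Cl`: 10 ug/mL
Compound 2 `CN(C)c1ccc(/C=N/C2=C(C#N)C(c3ccc(Cl)cc3Cl)C3=C(CCCC3=O)N2c2ccc(S(N)(=O)=O)cc2)cc1`: > 100 ug/mL, a limit and not a number

Compound 2 has no exact value, only (the limit of > 100 ug/mL in this assay, at which 1 of the 2 values shown sits). Compound 3 `CCO/C=N/C1=C(C#N)C(c2ccc(Cl)cc2Cl)C2=C(CCCC2=O)N1c1ccc(S(N)(=O)=O)cc1` differs from it by one change: ethoxy in place of 4-(dimethylamino)phenyl on a carbon with a double bond to nitrogen. Going by the values given here, the one measured step that bears on this is an at least 10-fold higher number from compound 1 to compound 2 (1.00 log units; beyond the scatter), which is the step that brought in the 4-(dimethylamino)phenyl group. Ethoxy removes that group, so part of that step may be reversed, and a move toward lower numbers in this assay is expected. Among the compounds with values here, the only exact value for comparison is that of compound 1, at 10 ug/mL. The expected step is an at least 3.3-fold lower number from compound 2 to compound 3 (0.52 log units; beyond the scatter). For compound 3 the estimated value is 30 ug/mL, with an expected range from 8 ug/mL to 100 ug/mL.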

Compound 3, half-maximal inhibitory concentration: > 100 ug/mL
Compound 3: no number, only a limit; the forecaster's own chance of this, stated with the estimate: 25%; middle value at least 3.3-fold (0.52 log units) away from the limit.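

In this assay, compound 3 gives only a limit, > 100 ug/mL, so ethoxy in place of 4-(dimethylamino)phenyl on a carbon with a double bond to nitrogen yields no exact value in this series. Compound 2 carries a six-membered aromatic ring in this group and compound 3 has no ring there, yet compared with compound 1 the ringless group still gives an at least 10-fold higher number from compound 1 to compound 3 (1.00 log units; beyond the scatter), which shows that removing the 4-(dimethylamino)phenyl group alone does not return the number seen for compound 1. The step between compound 2 and compound 3 cannot be read, because both compounds stand at the same limit: the limit of > 100 ug/mL in this assay, at which 2 of the 3 values shown sit.

From the compounds shown here alone, whether an amine or a longer alkoxy chain in place of ethoxy on that carbon would give an exact value remains open. So does the size of any gap between compound 2 and compound 3.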